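Fluorine on the Aryl Ketone: From Benzoyl to Phenoxyacetyl

This account rests on a few compounds, and the source may have more. Where it says the series, first, only, none or still open, it means among the compounds named here.

This account follows four compounds that share a core and differ in the group attached to it. Compound 1 `CC1(C)C=C(n2ccccc2=O)c2cc(C(=O)c3ccccc3F)ccc2O1` carries a benzoyl group bearing one fluorine; in a functional assay (aorta) with Rattus norvegicus as the target (on this read-out lower numbers stand for lower potency and higher numbers for higher potency (the scale is a negative logarithm)), compound 1 gives 7.08. Compound 2 `CC1(C)C=C(n2ccccc2=O)c2cc(C(=O)c3c(F)cccc3F)ccc2O1` carries a second fluorine, and in this assay compound 2 gives 6.97. The change between them, fluoro in place of hydrogen on an aromatic carbon, made a step of a number 0.11 log units lower from compound 1 to compound 2 (within the scatter).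

Compound 3 `CC1(C)C=C(n2ccccc2=O)c2cc(OCC(=O)c3ccccc3)ccc2O1` replaces the benzoyl group with a benzoylmethyl ether; in this assay compound 3 gives 5.05, the lowest of the three measured numbers. How the core of compound 3 differs from the core of compound 1 is not broken down here.

Compound 4 `CC1(C)C=C(n2ccccc2=O)c2cc(OCC(=O)c3ccc(F)cc3)ccc2O1` is not yet measured. It differs from compound 3 by fluoro in place of hydrogen on an aromatic carbon. This is the same kind of change as that from compound 1 to compound 2, but not the same: in the earlier pair the fluorine entered ortho to a large group and meta to a fluoro group, whereas here it enters para to a large group. Because the earlier step was a number 0.11 log units lower from compound 1 to compound 2 (within the scatter), the step from compound 3 to compound 4 is expected to be similarly small, about no change at the digits printed from compound 3 to compound 4 (within the scatter). Compound 4 is therefore estimated at 5.05 in this assay, with a range from 4.5 to 5.6.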

Compound 4, logarithm of the reciprocal of the active concentration, log(1/C): 4.63
Compound 4: middle estimate off by 0.42 log units, on the high side, and the stated range covers the measured number.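

On the core of compound 3, fluoro in place of hydrogen on an aromatic carbon gave a number 0.42 log units lower from compound 3 to compound 4 (beyond the scatter), a modest step. Set beside the earlier step, it gives no sign that this change behaves differently on the two cores in this assay: the same change on two cores in this assay, a number 0.11 log units lower (within the scatter) from compound 1 to compound 2 and a number 0.42 log units lower (beyond the scatter) from compound 3 to compound 4, 0.31 log units apart, within the scatter of two such steps. This supports only a cautious carry-over across these two pairs, and it does not show that the step keeps one size from core to core, since there are just two pairs and the fluorine does not enter the same setting in both: in compound 4 it stands para to a large group, whereas in compound 2 it enters a ring that already carries a fluoro group.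

The compounds shown leave open what fluoro would do para to a large group on the core of compound 1, so place and core cannot yet be told apart as separate influences on the step. They also leave open how a chloro or methoxy group at that place on the phenyl ring, or a longer chain between the ether oxygen and the carbonyl, would read in this assay.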